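This account rests on a few compounds, and the source may have more. Where it says the series, first, only, none or still open, it means among the compounds named here.

The story begins with compound 1 `O=C(Nc1ccccc1)N1c2ccnn2CC1c1ccccc1` and compound 2 `O=C(Nc1cccc(F)c1)N1c2ccnn2CC1c1ccccc1`, which share one core. In a functional assay on cells (Neutrophil, Homo sapiens) for inhibition, with a stated time of 10 min (on this read-out higher numbers stand for weaker inhibition and lower numbers for stronger inhibition), compound 1 gives > 1000 nM, a limit of the assay and not a number. Compound 2 gives > 1000 nM, also a limit and not a number. Compound 2 therefore stands at the limit of > 1000 nM in this assay, at which 2 of the 2 values shown sit. Fluoro in place of hydrogen on an aromatic carbon is the only measured change, and it is a step that the two limits leave unreadable from compound 1 to compound 2.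

Compound 3 `O=C(Nc1ccc(F)cc1)N1c2ccnn2CC1c1ccccc1` changes the fluorinated ring: 4-fluorophenyl in place of 3-fluorophenyl on an amide-type nitrogen. In words, 4-fluorophenyl stands in place of 3-fluorophenyl on an amide-type nitrogen. Within the data shown here, the single measured guide, a step that the two limits leave unreadable from compound 1 to compound 2, offers no size to carry forward. No shift beyond the scatter is therefore expected in this assay, and another limit is the likeliest report. The estimated step is a step that the limit leaves unreadable from compound 2 to compound 3. The expected value for compound 3 is 2000 nM, within an estimated range of 500 nM to 10000 nM.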

Compound 3, half-maximal inhibitory concentration: > 1000 nM
Compound 3 ended at the assay's limit; the forecaster's own chance of this, stated with the estimate: 75%; the middle value does not contradict the limit.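

Among these compounds, compound 3 gives only a limit and not a number, so no step among compound 1, compound 2 and compound 3 can be read in this assay: the limit of > 1000 nM in this assay, at which 3 of the 3 values shown sit. The compounds shown leave open how strongly any of the three inhibits, and whether fluoro or its position changes that at all.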